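Replacing the spiro amine of compound 1 with a fused bicyclic amine

The compounds below may be only part of what the source reports. "The series", "measured", "known", "first", "only" and "open" are said of these compounds alone.

The study measures compounds in a physicochemical assay for solubility, read by spectrophotometry, in phosphate buffer, with a stated time of 2 h, at pH 7.4; on this read-out lower numbers stand for lower solubility and higher numbers for higher solubility. Compound 1 `COc1ccc2[nH]c(C(=O)N3CC(=O)N(Cc4ccccc4)[C@@H](CCN4CCC5(CC4)CC5)C3)cc2c1` is known only as a limit of the assay: compound 1 gives > 25000 nM, and this reading is the limit of > 25000 nM in this assay, at which 1 of the 3 values shown sits. Two further compounds sharing the core were measured. Compound 2 `COc1ccc2[nH]c(C(=O)N3CC(=O)N(Cc4cc5ccccc5[nH]4)[C@@H](Cc4ccccc4)C3)cc2c1` gives 11000 nM, and compound 3 `COc1ccc2[nH]c(C(=O)N3CC(=O)N(Cc4cccc(OC(F)F)c4)[C@@H](CN4CCN(C5CC5)CC4)C3)cc2c1` gives 99600 nM. Compound 4 `COc1ccc2[nH]c(C(=O)N3CC(=O)N(Cc4ccccc4)[C@@H](CN4CCn5cccc5C4)C3)cc2c1` has not yet been measured. It differs from compound 1 in one place: a group of 9 heavy atoms (7 carbon, 2 nitrogen; one five-membered aromatic ring with 1 hetero atom, one six-membered non-aromatic ring with 2 hetero atoms) in place of a group of 9 heavy atoms (8 carbon, 1 nitrogen; one three-membered non-aromatic ring of carbon only, one six-membered non-aromatic ring with 1 hetero atom), on a saturated chain carbon bound to a saturated ring carbon. Going by the values given here, no measured step between two compounds that differ in a single place is available, so the direction of this change is uncertain; a step of small size, not clearly beyond the scatter, is expected. Compound 4 is therefore estimated at 30000 nM, within 8000 nM to 100000 nM, which would mean an expected step that the limit leaves unreadable from compound 1 to compound 4.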

Compound 4, solubility: 29700 nM
The estimate for compound 4 lay 1.0-fold (0.00 log units) above the measured number, within the range that was stated.
By their numbers in this assay, from the lowest: compound 2; then compound 4; then compound 3.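

No step from compound 1 to compound 4 can be read, because compound 1 is known only as a limit: the limit of > 25000 nM in this assay, at which 1 of the 4 values shown sits.

The compounds shown leave open how the group entering in compound 4 truly compares with the group it replaces from compound 1 in this assay.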